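The source may report more compounds than this note shows. Statements on the series, on what has been measured and on what is new or still open speak of the compounds shown alone.

Compound 1 `Cc1cc(-c2ccccc2NCC2=NCCN2)on1`: 38.9 nM
Compound 2 `Cc1nc(-c2ccccc2NCC2=NCCN2)no1`: 724 nM
Compound 3 `CO/N=C(\C)c1ccccc1NCC1=NCCN1`: 20.9 nM

All three compounds share a core and were tested in a functional assay for activation of Alpha-1A adrenergic receptor (Homo sapiens), read by calcium flux; on this read-out higher numbers stand for an effect only at larger amounts of compound and lower numbers for an effect already at smaller amounts. Compound 3 gives the lowest number of the three, but the step of a 1.9-fold lower number from compound 1 to compound 3 (0.27 log units; within the scatter) lies within the scatter, so compounds 1 and 3 cannot be told apart, whereas the step of a 35-fold lower number from compound 2 to compound 3 (1.54 log units; beyond the scatter) is large, as is the step of a 19-fold higher number from compound 1 to compound 2 (1.27 log units; beyond the scatter).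

Compound 4 `CO/N=C/c1ccccc1NCC1=NCCN1` differs from compound 3 in one place: a group of 4 heavy atoms (2 carbon, 1 nitrogen, 1 oxygen; no ring) in place of a group of 5 heavy atoms (3 carbon, 1 nitrogen, 1 oxygen; no ring), on an aromatic carbon. For the measured compounds named here, none of the measured steps concerns this exact change; they all exchange one five-membered ring for another or a ring for the open chain. The step of a 19-fold higher number from compound 1 to compound 2 (1.27 log units; beyond the scatter) shows that swapping rings can shift the number strongly, while the step of a 1.9-fold lower number from compound 1 to compound 3 (0.27 log units; within the scatter) shows that trading a ring for the open chain left the number within the scatter. Shortening the chain is a smaller alteration than either of those, so for compound 4 the expected step is a 1.4-fold higher number from compound 3 to compound 4 (0.16 log units; within the scatter), not beyond the scatter. Compound 4 is therefore estimated at 30 nM, with a range from 10 nM to 90 nM.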

Compound 4, half-maximal effective concentration: 51.3 nM
Estimate against measurement, compound 4: 1.7-fold (0.23 log units) below, within the range that was stated.
By their numbers in this assay, from the lowest: compounds 3, 1 and 4 (each within the scatter of the next, the first and the last beyond it); then compound 2.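

On this aromatic carbon, the open chain itself turns out to matter: in this assay, the group of 4 heavy atoms in place of the group of 5 gives a modest step that is larger than the usual scatter (a 2.5-fold higher number from compound 3 to compound 4 (0.39 log units; beyond the scatter)). This shorter chain still stands well apart from the ring of compound 2 (a 14-fold lower number from compound 2 to compound 4 (1.15 log units; beyond the scatter)). It cannot be told apart from the ring of compound 1, however (a 1.3-fold higher number from compound 1 to compound 4 (0.12 log units; within the scatter)), so a ring and an open chain can give similar numbers here. No evidence is available on what lies behind these differences.

The compounds shown leave open how a longer chain, such as a propyl group, would fare at this place. They also leave open whether an amine or a carboxylic acid on this aromatic carbon would keep the number low.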